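A few compounds are considered here, and "the series" means these few. Any claim that something is new, unique, unknown or untested is made for them only; others in the source may bear on it.

Measured in a functional assay on HeLa cells (Homo sapiens) for antiproliferative activity, read by CCK-8 assay, with a stated time of 72 h; on this read-out lower numbers stand for stronger inhibition and higher numbers for weaker inhibition:
- compound 1 `COc1ccc(-c2cncnc2-c2cc(OC)c(OC)c(OC)c2)cc1F`: 500 nM
- compound 2 `CCSc1ccc(-c2cncnc2-c2cc(OC)c(OC)c(OC)c2)cc1`: 370 nM

Going by the values given here, compound 2 stands level with compound 1, the only other measured compound, since the gap is a 1.4-fold lower number from compound 1 to compound 2 (0.13 log units; within the scatter). Compound 3 `COc1ccc(-c2cncnc2-c2cc(OC)c(OC)c(OC)c2)nc1` carries 5-methoxypyridin-2-yl in place of 4-(ethylsulfanyl)phenyl on an aromatic carbon. Among the compounds with values here, only that one measured step, made at the same place, bears on this change, and it stayed small. Neither measured compound has a hetero atom in this ring, so the expectation is uncertain. The expected change in this assay is modest and upward, namely a 1.9-fold higher number from compound 2 to compound 3 (0.28 log units; within the scatter). Compound 3 is estimated at 700 nM, with an expected range of 200 nM to 3000 nM.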

Compound 3, half-maximal inhibitory concentration: 470 nM
The estimate for compound 3 lay 1.5-fold (0.17 log units) above the measured number, within the range that was stated.
By their numbers in this assay, from the lowest: compounds 2, 3 and 1 (each within the scatter of the next).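

In this assay, going by these compounds alone, 5-methoxypyridin-2-yl is the first group at this position with a hetero atom in its ring, and it stays level with both groups that carry a ring of carbon only (a 1.3-fold higher number from compound 2 to compound 3 (0.10 log units; within the scatter); a 1.1-fold lower number from compound 1 to compound 3 (0.03 log units; within the scatter)). Across compounds 1, 2 and 3, this position therefore accepts a ring nitrogen with no change beyond the scatter. No supporting data explain why these numbers stay level. Going by these compounds, whether an amine or a carboxylic acid on this ring, or a longer chain in place of the ethylsulfanyl group, would shift the number remains open.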